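This account rests on a few compounds, and the source may have more. Where it says the series, first, only, none or still open, it means among the compounds named here.

In a functional assay on HCT-116 cells (Homo sapiens) for inhibition (a lower number here means that less compound is needed, a higher number that more compound is needed for the effect), compound 1 (`COc1cc(N2CCNCC2)ccc1Nc1nc(NC2CCCCC2)c2nc[nH]c2n1`) gives 160 nM and compound 2 (`COc1cc(N2CCN(C(=O)N3CCC(O)C3)CC2)ccc1Nc1nc(NC2CCCCC2)c2nc[nH]c2n1`) gives 100 nM, so the two stand within the scatter of each other. Within the data shown here, the only measured step is a 1.6-fold lower number from compound 1 to compound 2 (0.20 log units; within the scatter), with (3-hydroxypyrrolidin-1-yl)carbonyl in place of hydrogen on an amine nitrogen in a ring. Compound 3 (`CCN(CC)CC1CCN(c2ccc(Nc3nc(NC4CCCCC4)c4nc[nH]c4n3)c(OC)c2)CC1`) keeps the core of compound 1 but carries 4-((diethylamino)methyl)piperidin-1-yl in place of piperazin-1-yl on an aromatic carbon. Among the measured compounds shown here, no measured pair exchanges the piperazin-1-yl ring itself, so the step to compound 2 is only an indirect guide. Given that small step, a 1.6-fold lower number from compound 1 to compound 2 (0.20 log units; within the scatter), no change beyond the scatter is expected in this assay, and the estimated step is a 1.2-fold lower number from compound 1 to compound 3 (0.09 log units; within the scatter). For compound 3 the estimated value is 130 nM, with an expected range from 40 nM to 420 nM.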

Compound 3, half-maximal effective concentration: 55 nM
Compound 3: middle estimate off by 2.4-fold (0.37 log units), on the high side; the range from low to high includes it.
By their numbers in this assay, from the lowest: compounds 3, 2 and 1 (each within the scatter of the next, the first and the last beyond it).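

In this assay, the exchange of piperazin-1-yl for 4-((diethylamino)methyl)piperidin-1-yl on the aromatic carbon meta to the methoxy group gives a 2.9-fold lower number from compound 1 to compound 3 (0.46 log units; beyond the scatter). The earlier step, made on the ring nitrogen of the piperazine, stayed within the scatter, whereas this exchange of the whole ring moves the number beyond it, if only modestly. The position therefore accepts a group of 12 heavy atoms in place of one of 6, with no hydrogen-bond donor left in it, and without any loss in this assay. Nothing at hand explains this shift.

The compounds shown do not separate the contribution of the piperidine ring from that of the diethylamino end. A plain piperidin-1-yl ring, a morpholin-4-yl ring or a dimethylamino end group would each bear on that question.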